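The source may hold more compounds than are shown below. What is called first, only, known or untested is meant among the compounds shown, and "the series" means these compounds.

Measured compounds:
Compound 1, `Cc1c(C2CC2)nc2ccc(-n3ccc(OCc4ccccc4)cc3=O)cn12`: 42 nM
Compound 2, `Cc1c(C2CC2)nc2ccc(-n3ccc(OCc4ccc(F)cc4)cc3=O)cn12`: 47 nM
Compound 3, `Cc1c(C2CC2)nc2ccc(-n3ccc(OCc4ccc(C(C)C)cc4)cc3=O)cn12`: 410 nM

In an assay on CHO cells for displacement of a labelled ligand from melanin-concentrating hormone receptor 1 (Homo sapiens), read by scintillation counting, with a stated time of 1 h (on this read-out higher numbers stand for weaker inhibition and lower numbers for stronger inhibition), compound 1 gives 42 nM, compound 2 gives 47 nM and compound 3 gives 410 nM. All three share one core and differ only in the group on the benzyl ring. Compound 2 sits alongside compound 1, the two numbers being practically the same: a 1.1-fold higher number from compound 1 to compound 2 (0.05 log units; within the scatter). It is well apart from compound 3: an 8.7-fold higher number from compound 2 to compound 3 (0.94 log units; beyond the scatter), and in the same way a 9.8-fold higher number from compound 1 to compound 3 (0.99 log units; beyond the scatter).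

Compound 4, `COCc1nc2ccc(-n3ccc(OCc4ccc(F)cc4)cc3=O)cn2c1C`, changes a different part of the molecule: methoxymethyl in place of cyclopropyl on an aromatic carbon. The benzyl ring of compound 4 is the same as in compound 2. For the measured compounds named here, none of the measured steps touches the five-membered ring, so no measured step bears directly on this change, and the size and direction of its effect are unknown. The expectation therefore rests on compound 2 alone, with a wide margin on either side. For compound 4 the estimated value is 70 nM, expected to fall between 20 nM and 250 nM. That estimate means an expected step of a 1.5-fold higher number from compound 2 to compound 4 (0.17 log units; within the scatter), a step expected to stay within the scatter.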

Compound 4, half-maximal inhibitory concentration: > 1000 nM
Compound 4: no number, only a limit; the forecaster's own chance of this, stated with the estimate: 3%; middle value at least 14-fold (1.15 log units) away from the limit.
By their numbers in this assay, from the lowest: compounds 1 and 2 (each within the scatter of the next); then compound 3. At a limit, above all of these: compound 4.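

For the compounds shown here, the earlier compounds varied only the benzyl ring, so this is the first sign that the aromatic carbon carrying the cyclopropyl group matters too: in this assay, methoxymethyl in place of cyclopropyl gives an at least 21-fold higher number from compound 2 to compound 4 (1.32 log units; beyond the scatter). The two groups have the same count of heavy atoms, yet the change at this one place is large, so holding that count constant does not keep the inhibition. For compound 4 the reading of > 1000 nM is a limit of the assay and not a number: the limit of > 1000 nM in this assay, at which 1 of the 4 values shown sits.

The swap removes a ring and brings in an oxygen at once, and this single pair cannot show which of the two matters; a propyl chain, with no ring and no oxygen, or a tetrahydrofuranyl ring, with both, would pull them apart. On these data alone, it also remains open how far compound 4 really lies from compound 2, and whether the same swap has a similar effect with a different group on the benzyl ring.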